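The source may hold more compounds than are shown below. What is called first, only, known or untested is meant among the compounds shown, and "the series" means these compounds.

In a functional assay on ZR-75-30 cells (Homo sapiens) for cytotoxicity, read by MTT assay (a lower number here means a stronger inhibitor, a higher number a weaker inhibitor), compound 1 `COc1cc2ncnc(Nc3cc(O)[nH]n3)c2cc1OC` gives < 100000 nM, which is a limit of the assay and not a number. Compound 2 `COc1cc2ncnc(Nc3cc(-c4ccc(F)cc4)[nH]n3)c2cc1OC` also gives only a limit, < 100000 nM. Among the measured compounds shown here, the one measured step is a step that the two limits leave unreadable from compound 1 to compound 2, so it offers no size to build on. Compound 3 `COc1cc2ncnc(Nc3cc(-c4ccc(Cl)cc4)[nH]n3)c2cc1OC` carries chloro in place of fluoro on an aromatic carbon, para to a large group: chloro in place of fluoro on an aromatic carbon. For the measured compounds named here, the only guide is the limit of < 100000 nM in this assay, at which 2 of the 2 values shown sit, so no step beyond the scatter is expected in this assay. The expected step is a step that the limit leaves unreadable from compound 2 to compound 3. For compound 3 the estimated value is 20000 nM, with an expected range of 4000 nM to 90000 nM.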

Compound 3, half-maximal inhibitory concentration: 91500 nM
Estimate against measurement, compound 3: 4.6-fold (0.66 log units) below; the measured number lies above the stated range.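

Among the compounds shown here, no step to compound 3 can be read: compound 1 and compound 2 give only limits of the assay, not numbers. As far as these compounds go, whether compound 3 is a stronger or weaker inhibitor than either of them stays open.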